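Swapping chloro for fluoro on a benzyl group

The compounds below may be only part of what the source reports. "The series", "measured", "known", "first", "only" and "open" are said of these compounds alone.

Of the compounds shown here, three sharing one core have been tested in an assay for inhibition of histone acetyltransferase KAT2B (Homo sapiens), read by fluorescence; on this read-out lower numbers stand for stronger inhibition and higher numbers for weaker inhibition. Compound 1 `O=c1c2cc([N+](=O)[O-])cnc2sn1-c1ccc([N+](=O)[O-])cc1` gives 11800 nM. Compound 2 `O=c1c2cccnc2sn1Cc1ccc(Cl)cc1` gives 17500 nM, the highest number of the three; its gap to compound 1 lies within the scatter, so no order can be read between those two. Compound 3 `O=c1c2cccnc2sn1-c1ccccc1` gives 7850 nM, a number that lies beyond the scatter below the number for compound 2, so compound 3 inhibits more strongly than compound 2.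

Compound 4 `O=c1c2cccnc2sn1Cc1ccc(F)cc1` has not yet been measured. It differs from compound 2 by fluoro in place of chloro on an aromatic carbon, para to a large group. Going by the values given here, no measured pair shows what this exchange does on this core, so the expectation rests only on the size of the change, one halogen for another at the same place. A step that stays within the scatter is expected in this assay, with no clear direction. Compound 4 is therefore expected to give about 20000 nM, with a range from 8000 nM to 50000 nM. The step of a 1.1-fold higher number from compound 2 to compound 4 (0.06 log units; within the scatter) that this estimate means is expected to be small.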

Compound 4, half-maximal inhibitory concentration: 86300 nM
Compound 4: middle estimate off by 4.3-fold (0.63 log units), on the low side; measured number outside the range, above it.
By their numbers in this assay, from the lowest: compounds 3, 1 and 2 (each within the scatter of the next, the first and the last beyond it); then compound 4.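

In this assay, fluoro in place of chloro on the aromatic carbon gives a 4.9-fold higher number from compound 2 to compound 4 (0.69 log units; beyond the scatter) and so weaker inhibition, which makes this more than a minor exchange of one halogen for another. The group at this place, para to a large group, therefore matters on this core, and of these two halogens, chloro goes with the stronger inhibition. Nothing at hand explains why exchanging this single atom has such an effect.

Going by these compounds, with only two halogens compared here, what bromo, a methyl group or a methoxy group would give at the same place stays open. Also open, on these data alone, is whether plain hydrogen, with no halogen at all, would give a number closer to that of compound 2 or compound 4.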